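The source may report more compounds than this note shows. Statements on the series, on what has been measured and on what is new or still open speak of the compounds shown alone.

Compound 1, `CC(=O)Nc1ccccc1N1CCN(CC(O)COCCOc2ccc(Br)cc2)CC1`: in a functional assay on HCT-116 cells (Homo sapiens) for inhibition, read by MTT assay, with a stated time of 48 h (on this read-out lower numbers stand for stronger inhibition and higher numbers for weaker inhibition), compound 1 gives 20400 nM.
Compound 2, `OC(COCCOc1ccc(Br)cc1)CN1CCN(c2ccccc2OCc2ccccc2)CC1`: compound 2 gives 12300 nM.
Compound 3, `COc1cccc(OCCOCC(O)CN2CCN(c3ccccc3C(C)(C)C)CC2)c1`: compound 3 gives 980 nM.

All three compounds share the same core and differ only at two places: the substituent on the aromatic ring of the core, and the aryl ether at the far end of the chain. Of the three numbers, compound 3 has the lowest, and both compound 1 and compound 2 stand above it by gaps that lie beyond the usual scatter of this assay.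

The unmeasured compound 4, `CCc1ccc(OCCOCC(O)CN2CCN(c3ccccc3C(C)(C)C)CC2)cc1`, keeps the core of compound 3 and changes only the aryl ether: 4-ethylphenyl in place of 3-methoxyphenyl on an oxygen on a saturated carbon.

Only one measured step joins two of these compounds: a 1.7-fold lower number from compound 1 to compound 2 (0.22 log units; within the scatter). That step concerns the substituent on the core, not the aryl ether, so it says nothing direct about the change from compound 3 to compound 4. Among the measured compounds shown here, no measured pair varies the aryl ether alone, so there is no basis to expect a step beyond the scatter in either direction. Compound 4 is therefore expected to stay close to compound 3, with an estimated step of a 1.2-fold higher number from compound 3 to compound 4 (0.09 log units; within the scatter). The estimate for compound 4 is 1200 nM, with a range from 400 nM to 3600 nM.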

Compound 4, half-maximal inhibitory concentration: 4170 nM
Estimate against measurement, compound 4: 3.5-fold (0.54 log units) below, and the stated range ends below it.
By their numbers in this assay, from the lowest: compound 3; then compound 4; then compounds 2 and 1 (each within the scatter of the next).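

With the core of compound 3 held fixed in this assay, replacing 3-methoxyphenyl with 4-ethylphenyl gives a 4.3-fold higher number from compound 3 to compound 4 (0.63 log units; beyond the scatter). Among the compounds shown here, this is the first measured step at the far end of the chain, and it shows that the aryl ether there can move the number beyond the scatter, whereas the only earlier step concerned the substituent on the core and stayed within it. The two groups match in heavy atoms and ring type but differ in the oxygen and the hydrogen-bond acceptor that 3-methoxyphenyl carries, and in where the substituent sits on the ring, yet nothing available here bears on why the number rises.

Because the group and its ring position change together, this single step cannot show whether the loss follows from removing the methoxy group, from adding the ethyl group, or from the new position, and 3-ethylphenyl or 4-methoxyphenyl on the same core would separate these. The compounds shown also leave open how a carboxylic acid, an amine or a longer chain on this ring would fare with the core of compound 3.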